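The source may report more compounds than this note shows. Statements on the series, on what has been measured and on what is new or still open speak of the compounds shown alone.

Measured so far in a functional assay on DU-145 cells (Homo sapiens) for cytotoxicity, read by trypan blue exclusion, with a stated time of 96 h; a lower number here means a stronger inhibitor, a higher number a weaker inhibitor
- compound 1 `COc1cc(OC)c(/C=C/S(=O)(=O)Nc2ccc(OC)c(OP(=O)(O)O)c2)c(OC)c1` gives 40 nM
- compound 2 `COc1cc(OC)c(/C=C/S(=O)(=O)Nc2ccc(OC)c(N)c2)c(OC)c1` gives 5 nM
- compound 3 `COc1ccc(NS(=O)(=O)/C=C/c2c(OC)cc(OCCCC(=O)O)cc2OC)cc1N` gives 10000 nM

Compound 2 has the lowest number of the three, with both others beyond the scatter from it. Compound 4 `COC(=O)C(Nc1cc(NS(=O)(=O)/C=C/c2c(OC)cc(OC)cc2OC)ccc1OC)c1ccc(Cl)cc1` is not yet measured and differs from compound 2 by (4-chlorophenyl)(methoxycarbonyl)methyl in place of hydrogen on a nitrogen on an aromatic ring. Among the compounds with values here, no measured step changes that nitrogen in this way, so the evidence is indirect. Within the data shown here, two steps bear on it: the modest 8.0-fold lower number from compound 1 to compound 2 (0.90 log units; beyond the scatter) involves a group on an aromatic carbon, and the large 2000-fold higher number from compound 2 to compound 3 (3.30 log units; beyond the scatter) involves a saturated chain carbon. Both leave compound 2 as the lowest number, so a higher number is expected, of a size between those two steps. The expected step is a 20-fold higher number from compound 2 to compound 4 (1.30 log units; beyond the scatter). Compound 4 is estimated at 100 nM, with an expected range from 10 nM to 1000 nM.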

Compound 4, half-maximal inhibitory concentration: 5000 nM
Estimate against measurement, compound 4: 50-fold (1.70 log units) below, outside the stated range (above it).
By their numbers in this assay, from the lowest: compound 2; then compound 1; then compounds 4 and 3 (each within the scatter of the next).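

In this assay, within the data shown here, the nitrogen on the aromatic ring is changed directly for the first time: (4-chlorophenyl)(methoxycarbonyl)methyl in place of hydrogen gives a 1000-fold higher number from compound 2 to compound 4 (3.00 log units; beyond the scatter). This position therefore does not keep the low number of compound 2 with this substituent, which brings 12 heavy atoms, including a six-membered aromatic ring. No measurement available here accounts for the step.

Which part of the entering group carries the step remains open. So does the outcome with a single methyl or an acetyl on this nitrogen, or with a carboxylic acid in place of the methyl ester.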